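The compounds below may be only part of what the source reports. "The series", "measured", "known", "first", "only" and "open" are said of these compounds alone.

Working notes on the furan-type amide series. The shared core carries a vinyl group and an aryl substituent on the oxygen-bearing ring, with the amide nitrogen varied. Compound 1 `C=CC1=C(C(=O)NCc2ccccc2)C(c2ccc(OC)cc2)OC1` bears a benzyl amide. In a functional assay on HeLa cells (Homo sapiens) for cytotoxicity, read by MTT assay, with a stated time of 24 h (a lower number here means a stronger inhibitor, a higher number a weaker inhibitor), compound 1 gives > 100000 nM, which is a limit of the assay and not a number. Compound 2 `C=CC1=C(C(=O)Nc2ccc(OCC)cc2)C(c2ccc(OC)cc2)OC1` carries a 4-ethoxyphenyl amide instead. In this assay compound 2 gives > 100000 nM, again a limit. The step that the two limits leave unreadable from compound 1 to compound 2 is therefore unreadable. Within the data shown here, compound 3 `C=CC1=C(C(=O)NC2CCCCC2)C(c2ccc(OC)c(OC)c2)OC1` has a cyclohexyl amide and a dimethoxyphenyl substituent; in this assay compound 3 gives 5540 nM, the only actual number in the set, since the limit of > 100000 nM in this assay, at which 2 of the 3 values shown sit, accounts for the other two values. Among the measured compounds shown here, compound 3 differs from compound 1 and from compound 2 in two places, so no single step links it to either.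

Compound 4 `C=CC1=C(C(=O)NC2CCCCC2)C(c2ccc(OC)cc2)OC1` is obtained from compound 3 by hydrogen in place of methoxy on an aromatic carbon. For the measured compounds named here, no measured step touches the aryl ring; the only readable pair, compound 1 and compound 2, changes the amide nitrogen and is unreadable in size. Expectation rests on the numbers shown alone: compound 3 is the single active point, and removing a methoxy is taken as a change within or slightly beyond the scatter, towards weaker. Compound 4 is expected to give 12000 nM, in the range 3000 nM to 60000 nM. The expected step is a 2.2-fold higher number from compound 3 to compound 4 (0.34 log units; beyond the scatter), with a real chance that only a limit is reported.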

Compound 4, half-maximal inhibitory concentration: 24800 nM
Beside the measured number, compound 4's estimate is 2.1-fold (0.32 log units) below it; the measured number falls inside the stated range.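

In this assay, the aryl ring now gives its first readable step: hydrogen in place of the methoxy group that sits ortho to a methoxy group and meta to a large group gives a 4.5-fold higher number from compound 3 to compound 4 (0.65 log units; beyond the scatter), so with the cyclohexyl amide held fixed, this one methoxy group separates two measured values. With the aryl group of compound 4 shared by compound 1 and compound 2, the amide nitrogen also becomes readable: cyclohexyl in place of 4-ethoxyphenyl gives an at least 4.0-fold lower number from compound 2 to compound 4 (0.60 log units; beyond the scatter), and cyclohexyl in place of benzyl gives an at least 4.0-fold lower number from compound 1 to compound 4 (0.60 log units; beyond the scatter). Both amide steps are bounds and not exact sizes, and neither sets the two aromatic amide groups apart: the limit of > 100000 nM in this assay, at which 2 of the 4 values shown sit.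

Going by these compounds, whether a hydroxy group or a fluorine in place of this methoxy group would fall with compound 3, with compound 4 or elsewhere remains open, as does the result of the same methoxy change on the benzyl or 4-ethoxyphenyl amide. On these data alone, on the amide nitrogen, it is also open whether the cyclohexyl ring itself matters or whether an open hexyl chain or a cyclopentyl ring would read the same.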